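The source may hold more compounds than are shown below. What is called first, only, known or untested is meant among the compounds shown, and "the series" means these compounds.

The series opens with compound 1, `C[C@@H](NC(=O)c1ccc(C#Cc2ccc(F)cn2)cn1)C(C)(C)O`, which in an ADME assay on HEK293 cells for agonist activity at metabotropic glutamate receptor 5 (Rattus norvegicus), read by fluorescence and calcium flux (on this read-out lower numbers stand for smaller maximal responses and higher numbers for larger maximal responses), gives 13.5%. For the measured compounds named here, compound 2, `C[C@@H](NC(=O)c1ccc(C#Cc2cccc(F)c2)cn1)C(C)(C)C`, differs from it in more than one place, so no single step connects the two; in this assay compound 2 gives 31.2%. Among the two measured numbers compound 2 stands highest, and the nearest value, that of compound 1, sits below it by a gap that lies beyond the usual scatter.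

Compound 3, `CC(C)[C@H](C)NC(=O)c1ccc(C#Cc2cccc(F)c2)cn1`, has not yet been measured in this assay. It arises from compound 2 by one change on the side chain bound to the amide nitrogen: 1,2-dimethylpropyl in place of 1,2,2-trimethylpropyl on an amide-type nitrogen. The two groups carry no donors, no acceptors and no ring, and the change removes one carbon from a branched chain. Going by the values given here, no measured pair in this set shows what such a change does, so only a cautious expectation is possible. The account expects a step of a number 3.2 percentage points lower from compound 2 to compound 3 (within the scatter), that is, a change that stays within the scatter rather than a clear rise or fall. Compound 3 is therefore estimated at 28%, with a range from 12% to 45%.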

Compound 3, largest response reached (reported as efficacy), in percent of the reference or control that the assay uses: 13.1%
Compound 3: middle estimate off by 14.9 percentage points, on the high side; the measured number falls inside the stated range.
By their numbers in this assay, from the lowest: compounds 3 and 1 (each within the scatter of the next); then compound 2.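

The side chain on the amide-type nitrogen proves to matter in this assay: with the rest of the molecule unchanged, 1,2-dimethylpropyl in place of 1,2,2-trimethylpropyl gives a number 18.1 percentage points lower from compound 2 to compound 3 (beyond the scatter), so the loss of one carbon from this branched chain is enough to shift the maximal response clearly. Compound 1 and compound 2 differ in more than one place, so their gap could not be assigned to any one group, whereas this step ties a change in the response to this position alone. Nothing in the data at hand explains how this single carbon produces such a shift.

A single step leaves open whether the response follows the size of this chain in any regular way, and what a longer chain such as n-butyl, a cyclohexyl ring or an amine would give on the same nitrogen. Going by these compounds, it also remains open whether the same change would produce a step of similar size with the other end of the molecule as it stands in compound 1.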